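Para-halogen swap on the phenylpiperazine of the shared core

The source may report more compounds than this note shows. Statements on the series, on what has been measured and on what is new or still open speak of the compounds shown alone.

Compound 1 `CCOC(=O)c1c(N2CCN(C)CC2)[nH]c2ccc(O)cc12` carries a methyl on the piperazine nitrogen; in an assay on isolated protein for inhibition of Polyunsaturated fatty acid 5-lipoxygenase (Homo sapiens), tested at 10 uM (a lower number here means less inhibition, a higher number more inhibition at the concentration tested (going by the name of the read-out)), compound 1 gives "not determined" (no result reported). Compound 2 `CCOC(=O)c1c(N2CCN(c3ccccc3)CC2)[nH]c2ccc(O)cc12` bears a phenyl there and gives 79%; compound 3 `CCOC(=O)c1c(N2CCN(c3ccc(F)cc3)CC2)[nH]c2ccc(O)cc12` is its 4-fluorophenyl analogue and gives 81%. Among the measured compounds shown here, the single step with numbers on both sides, a number 2 percentage points higher from compound 2 to compound 3 (within the scatter), is within the scatter, so fluoro in place of hydrogen on that ring leaves the read-out where it was. On the numbers shown compound 3 stands level with compound 2 within the scatter; these are the only two results reported in the series.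

Compound 4 `CCOC(=O)c1c(N2CCN(c3ccc(Cl)cc3)CC2)[nH]c2ccc(O)cc12` differs from compound 3 by chloro in place of fluoro on an aromatic carbon. For the measured compounds named here, no measured step covers chloro in place of fluoro; the only step that bears on it is a number 2 percentage points higher from compound 2 to compound 3 (within the scatter), which shows that exchanging the substituent para to a large group on this phenyl, hydrogen for fluoro, did nothing beyond the scatter. The second halogen exchange is expected to behave alike, so the step of a number 1 percentage points higher from compound 3 to compound 4 (within the scatter) is estimated to fall within the scatter, with no direction implied. Compound 4 is therefore expected to give 82% in this assay, within the range 70% to 92%.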

Compound 4, a percentage reported as inhibition, at one concentration (the size of the read-out at that concentration, not a potency): 69%
Compound 4: the middle estimate sits 13 percentage points above what was measured; the whole stated range lies above it.
By their numbers in this assay, from the lowest: compounds 4, 2 and 3 (each within the scatter of the next, the first and the last beyond it).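

In this assay, among the compounds shown here, the aromatic carbon para to a large group proves less indifferent to its substituent than the hydrogen-to-fluoro exchange suggested: chloro in place of fluoro gives a number 12 percentage points lower from compound 3 to compound 4 (beyond the scatter), the only step that lies beyond the scatter. Measured against the unsubstituted phenyl, the same chloro gives a number 10 percentage points lower from compound 2 to compound 4 (within the scatter), so the drop holds only against the fluoro analogue, and these values do not establish that chloro itself lowers inhibition relative to hydrogen. Nothing available here accounts for the difference between fluoro and chloro at this position.

Going by these compounds, whether the read-out follows the halogen at this carbon stays open, and bromo or iodo there, or a methoxy or trifluoromethyl group, would be needed to tell a trend from a single pair of values. On these data alone, the scope at the piperazine nitrogen beyond phenyl rings also stays open, as compound 1 with its methyl gives "not determined" (no result reported), and a benzyl group or a longer chain at that nitrogen would bear on this question.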